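Iodo in place of hydrogen on the shared core

The compounds below may be only part of what the source reports. "The series", "measured", "known", "first", "only" and "open" are said of these compounds alone.

compound 1 `C=CC(=O)Nc1cc(Nc2ncc(Cl)c(Nc3ccccc3S(=O)(=O)C(C)C)n2)c(OC)cc1N(C)CCN(C)C`: 12%
compound 2 `C=CC(=O)Nc1cc(Nc2ncc(F)c(Nc3ccccc3S(=O)(=O)C(C)C)n2)c(OC)cc1N(C)CCN(C)C`: 15%
compound 3 `C=CC(=O)Nc1cc(Nc2nccc(Nc3ccccc3S(=O)(=O)C(C)C)n2)c(OC)cc1N(C)CCN(C)C`: 8%

In an ADME assay on microsomes from liver (Mus musculus) for metabolic stability, read by LC-MS, using NADPH, with a stated time of 30 min, tested at 1 uM (a lower number here means that less of the compound is left, a higher number that more of the compound is left), compound 3 gives 8%, within the scatter of the other two compounds. Compound 4 `C=CC(=O)Nc1cc(Nc2ncc(I)c(Nc3ccccc3S(=O)(=O)C(C)C)n2)c(OC)cc1N(C)CCN(C)C` has not been measured. Its difference from compound 3 is iodo in place of hydrogen on an aromatic carbon. Among the measured compounds shown here, no iodo compound has a measured value, so the nearest evidence is the three halogen and hydrogen steps: a number 3 percentage points higher from compound 1 to compound 2 (within the scatter), a number 4 percentage points lower from compound 1 to compound 3 (within the scatter) and a number 7 percentage points lower from compound 2 to compound 3 (within the scatter). On these data alone, since all three stay within the scatter, no step beyond the scatter is expected in this assay, and its direction stays open. The expected step is a number 3 percentage points higher from compound 3 to compound 4 (within the scatter). The estimate for compound 4 is 11%, with an expected range from 4% to 22%.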

Compound 4, percent of the compound remaining: 10%
Estimate against measurement, compound 4: 1 percentage points above; the measured number falls inside the stated range.
By their numbers in this assay, from the lowest: compounds 3, 4, 1 and 2 (each within the scatter of the next).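

In this assay iodo at this position leaves the number within the scatter of all three earlier compounds, with a number 2 percentage points higher from compound 3 to compound 4 (within the scatter) and a number 5 percentage points lower from compound 2 to compound 4 (within the scatter) and a number 2 percentage points lower from compound 1 to compound 4 (within the scatter) as the steps. Hydrogen, fluoro, chloro and iodo on this aromatic carbon therefore cannot be told apart in this read-out. Nothing available bears on why the numbers stay together at this position.

On these data alone, whether a nitrile, a methyl or an amine on this carbon would give a step beyond the scatter stays open. So does whether this position can move the number at all.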